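Aryl urea series: bromo in place of acetyl

This account rests on a few compounds, and the source may have more. Where it says the series, first, only, none or still open, it means among the compounds named here.

Measured in an ADME assay on the whole organism with Oryza sativa as the target, tested at 0.1 uM; a higher number here means a weaker effect of the compound at the concentration tested, a lower number a stronger effect:
- compound 1 `CCc1ccc(NC(=O)N[C@H](C)c2ccccc2)cc1` gives 95%
- compound 2 `CCCCCCCc1ccc(NC(=O)N[C@H](C)c2ccccc2)cc1` gives 100%
- compound 3 `CC(=O)c1ccc(NC(=O)N[C@H](C)c2ccccc2)cc1` gives 96%

Compound 3 stands second highest of the three numbers. Its nearest neighbour is compound 1, with a number 1 percentage points higher from compound 1 to compound 3 (within the scatter); its furthest is compound 2, with a number 4 percentage points lower from compound 2 to compound 3 (within the scatter). Compound 4 `C[C@@H](NC(=O)Nc1ccc(Br)cc1)c1ccccc1` differs from compound 3 by bromo in place of acetyl on an aromatic carbon.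

Within the data shown here, the steps that bear on this change are the two earlier swaps on the same aromatic carbon, and both stayed within the scatter. No replacement at that carbon has yet moved the number beyond the scatter, so the expectation for compound 4 is a step of no change at the digits printed from compound 3 to compound 4 (within the scatter), none beyond the scatter. Compound 4 is estimated at 96%, between 86% and 100%.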

Compound 4, a percentage reported as activity, at one concentration (the size of the read-out at that concentration, not a potency): 100%
Estimate against measurement, compound 4: 4 percentage points below; low and high end bracket the measured number.
By their numbers in this assay, from the lowest: compounds 1, 3, 2 and 4 (each within the scatter of the next).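

In this assay, bromo on this aromatic carbon gives no step beyond the scatter against acetyl (a number 4 percentage points higher from compound 3 to compound 4 (within the scatter)), heptyl (no change at the digits printed from compound 2 to compound 4 (within the scatter)) or ethyl (a number 5 percentage points higher from compound 1 to compound 4 (within the scatter)). A halogen with one heavy atom and no hydrogen-bond acceptor therefore extends the flat reading at this position, which so far spans ethyl, heptyl, acetyl and bromo. No supporting measurement bears on this result.

As far as these compounds go, whether an amine or a carboxylic acid on this carbon would move the number beyond the scatter remains open. So does whether any change elsewhere on the shared core would.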